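Dichlorophenyl Isomers in an A549 Cytotoxicity Assay

The source may report more compounds than this note shows. Statements on the series, on what has been measured and on what is new or still open speak of the compounds shown alone.

Measured in a functional assay on A549 cells (Homo sapiens) for cytotoxicity, read by MTT assay, with a stated time of 72 h; on this read-out higher numbers stand for weaker inhibition and lower numbers for stronger inhibition:
- compound 1 `COc1ccc(/C=C2\CCC/C(=C\c3ccccc3Cl)C2=O)cc1OC`: > 20000 nM, a limit
- compound 2 `COc1ccc(/C=C2\CCC/C(=C\c3ccc(Cl)cc3)C2=O)cc1OC`: 10100 nM
- compound 3 `COc1ccc(/C=C2\CCC/C(=C\c3ccc(Cl)cc3Cl)C2=O)cc1OC`: > 20000 nM, a limit

Compound 3 stands only at a limit, (the limit of > 20000 nM in this assay, at which 2 of the 3 values shown sit). Compound 4 `COc1ccc(/C=C2\CCC/C(=C\c3ccc(Cl)c(Cl)c3)C2=O)cc1OC`, not yet measured, differs from it by 3,4-dichlorophenyl in place of 2,4-dichlorophenyl on a double-bonded chain carbon bound to a double-bonded ring carbon. Within the data shown here, two measured steps bear on this change: an at least 1.9-fold lower number from compound 1 to compound 2 (0.29 log units; that floor lies within the scatter) and an at least 1.9-fold higher number from compound 2 to compound 3 (0.29 log units; that floor lies within the scatter). Both floors lie within the scatter, so only a modest move toward a lower number is expected in this assay. The expected step is an at least 1.6-fold lower number from compound 3 to compound 4 (0.22 log units; that floor lies within the scatter). For compound 4 the estimated value is 12000 nM, with an expected range from 5000 nM to 25000 nM.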

Compound 4, half-maximal inhibitory concentration: 6900 nM
For compound 4 the middle estimate is 1.7-fold (0.24 log units) above the measured one, within the range that was stated.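

In this assay, among these compounds, 3,4-dichlorophenyl on this double-bonded chain carbon gives the first steps beyond the scatter, both against groups that stand at a limit (an at least 2.8-fold lower number from compound 3 to compound 4 (0.46 log units; beyond the scatter)) and (an at least 2.8-fold lower number from compound 1 to compound 4 (0.46 log units; beyond the scatter)). Against 4-chlorophenyl, the added chloro stays within the scatter (a 1.5-fold lower number from compound 2 to compound 4 (0.17 log units; within the scatter)). Compound 1 with 2-chlorophenyl and compound 3 with 2,4-dichlorophenyl each remain a limit and not a number: the limit of > 20000 nM in this assay, at which 2 of the 4 values shown sit.

The step between compound 1 and compound 3 cannot be read. Open too, as far as these compounds go, is how a nitrile or an amine in place of chloro on this aromatic ring would read in this assay.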